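Dropping the Hydroxy From Compound 2: What to Expect

This account rests on a few compounds, and the source may have more. Where it says the series, first, only, none or still open, it means among the compounds named here.

Compound 1, `O=C(Nc1ccc(O)cc1)C1CCc2ccccc2N1`: > 100000 nM
Compound 2, `O=C(Nc1ccccc1O)C1CCc2ccccc2N1`: 5610 nM

In a functional assay on HCT-15 cells (Homo sapiens) for cytotoxicity, read by sulforhodamine B assay, with a stated time of 72 h (a lower number here means a stronger inhibitor of growth, a higher number a weaker inhibitor of growth), compound 1 gives > 100000 nM, which is a limit of the assay, namely (the limit of > 100000 nM in this assay, at which 1 of the 2 values shown sits). Among the compounds with values here, compound 2 gives 5610 nM in this assay, the only actual number here. Compound 3, `O=C(Nc1ccccc1)C1CCc2ccccc2N1`, differs from compound 2 by hydrogen in place of hydroxy on an aromatic carbon. Within the data shown here, no step between measured compounds exists, so the size of this change in this assay can only be expected; a loss of potency beyond the scatter seems more likely than a gain. Compound 3 is therefore estimated at 25000 nM, with a range from 5000 nM to 100000 nM. The expected step is a 4.5-fold higher number from compound 2 to compound 3 (0.65 log units; beyond the scatter).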

Compound 3, concentration for 50% growth inhibition: 109000 nM
Compound 3: the middle estimate sits 4.4-fold (0.64 log units) below what was measured; the measured number lies above the stated range.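

In this assay, hydrogen in place of hydroxy on an aromatic carbon ortho to a large group gives a 19-fold higher number from compound 2 to compound 3 (1.29 log units; beyond the scatter), so within this pair the potency depends strongly on the hydroxy at this place. Compound 1 carries a limit, not a number, and its step to compound 3 cannot be read: the limit of > 100000 nM in this assay, at which 1 of the 3 values shown sits.

The compounds shown leave open whether another group at this place, such as a methoxy or an amine, would match compound 2. They also leave open whether a fluorine there would do so.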